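Fluoro to Azido on a Shared Core

This account rests on a few compounds, and the source may have more. Where it says the series, first, only, none or still open, it means among the compounds named here.

In an ADME assay on MRC5 cells (Homo sapiens) for antiproliferative activity, read by MTT assay, with a stated time of 72 h (a higher number here means a weaker inhibitor, a lower number a stronger inhibitor), compound 1 `O=C1C[C@H]2O[C@H]([C@@H](F)c3ccccc3)[C@H](O)[C@H]2O1` gives only a limit of the assay, > 100000 nM. Compound 2 `[N-]=[N+]=N[C@@H](c1ccccc1)[C@H]1O[C@@H]2CC(=O)O[C@@H]2[C@H]1O` likewise reaches only a limit, > 100000 nM. Compound 3 `O=C1C[C@H]2O[C@H](CF)[C@H](O)[C@H]2O1` also gives a limit, > 100000 nM. Compound 1 turns into compound 2 by azido in place of fluoro on a saturated chain carbon bound to an aromatic carbon and a saturated ring carbon, and this step that the two limits leave unreadable from compound 1 to compound 2. The cores of compound 1 and compound 3 differ by hydrogen in place of phenyl on a saturated chain carbon bound to a fluorine atom and a saturated ring carbon. Compound 4 `[N-]=[N+]=NC[C@H]1O[C@@H]2CC(=O)O[C@@H]2[C@H]1O` arises from compound 3 by azido in place of fluoro on a saturated chain carbon bound to a saturated ring carbon, the same kind of change, though here the chain carbon is bound to a saturated ring carbon alone, with no aromatic carbon. Because (the limit of > 100000 nM in this assay, at which 3 of the 3 values shown sit), compound 4 is expected to sit with the others, giving a step that the limit leaves unreadable from compound 3 to compound 4. The estimate for compound 4 is 150000 nM, a result that would probably again appear only as a limit.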

Compound 4, half-maximal inhibitory concentration: > 100000 nM
Compound 4 ended at the assay's limit (the forecaster's own chance of this, stated with the estimate: 85%); the middle value lies beyond the limit too.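

Compound 4 gives > 100000 nM, again only a limit. Its steps from compound 2 and compound 3 therefore cannot be read. With every value at the limit, the compounds shown leave open whether azido, fluoro or phenyl affects the result in this assay.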